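Piperidin-1-yl in place of dimethylamino: working notes

The compounds below may be only part of what the source reports. "The series", "measured", "known", "first", "only" and "open" are said of these compounds alone.

In a functional assay on NCH89 cells (Homo sapiens) for antiproliferative activity, read by BrdU incorporation, with a stated time of 48 h (a lower number here means a stronger inhibitor, a higher number a weaker inhibitor), compound 1 (`CC(C)NCCNc1ccnc2cc(Cl)ccc12`) gives 30400 nM. Compound 2 (`CN(C)CCC(NCCNc1ccnc2cc(Cl)ccc12)c1ccccc1`) gives 7300 nM, the lower of the two numbers, with a gap beyond the scatter. Compound 3 (`Clc1ccc2c(NCCNC(CCN3CCCCC3)c3ccccc3)ccnc2c1`) is not yet measured. It carries piperidin-1-yl in place of dimethylamino on a saturated chain carbon, three bonds along the chain from an amine nitrogen and an aromatic carbon. Among the measured compounds shown here, no measured pair shows this change. The expected step is small, a 1.5-fold lower number from compound 2 to compound 3 (0.16 log units; within the scatter), toward a lower number but within the scatter. For compound 3 the estimated value is 5000 nM, with an expected range of 2000 nM to 12000 nM.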

Compound 3, half-maximal inhibitory concentration: 5600 nM
Compound 3: the middle estimate sits 1.1-fold (0.05 log units) below what was measured, and the stated range covers the measured number.
By their numbers in this assay, from the lowest: compounds 3 and 2 (each within the scatter of the next); then compound 1.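

In this assay, replacing dimethylamino with piperidin-1-yl on this saturated chain carbon gives a 1.3-fold lower number from compound 2 to compound 3 (0.12 log units; within the scatter), within the scatter. This position therefore accepts a six-membered non-aromatic ring of 6 heavy atoms in place of a group of 3 without a change that can be read in this assay. No measured evidence bears on why the step is this small.

Still open, as far as these compounds go, is whether a morpholin-4-yl group or a primary amine would fit here equally well. From the compounds shown here alone, a longer chain carrying the piperidin-1-yl group also remains untested in these compounds.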